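Hydroxyacyl side chain: phenyl against tert-butyl on the shared core

The source may hold more compounds than are shown below. What is called first, only, known or untested is meant among the compounds shown, and "the series" means these compounds.

Working notes on the series. Three members have been run in an ADME assay on liver for metabolic stability, with Liver microsome (Homo sapiens) as the target, read by LC-MS, using microsomes; a higher number here means faster removal of the compound, a lower number slower removal. Compound 1 `CC(C)(C)[C@@H](O)C(=O)N1[C@@H]2C[C@@H]2C[C@H]1C(=O)NCc1cc(Cl)ccc1-n1cnnn1` gives 54 mL.min-1.g-1 in this assay, and compound 2 `CC(C)(C)C[C@@H](O)C(=O)N1CC[C@@H]2C[C@@]21C(=O)NCc1cc(Cl)ccc1-n1cnnn1` gives 27 mL.min-1.g-1; these two values sit within the usual scatter of each other. Compound 3 `O=C(NCc1cc(Cl)ccc1-n1cnnn1)[C@@H]1[C@@H]2C[C@@H]2CN1C(=O)[C@H](O)c1ccccc1` is reported in this assay only as a limit, < 15 mL.min-1.g-1, with no number behind it. Of the three, compound 3 alone sits at the limit of < 15 mL.min-1.g-1 in this assay, at which 1 of the 3 values shown sits.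

Compound 4 `CC(C)(C)[C@@H](O)C(=O)N1C[C@H]2C[C@H]2[C@H]1C(=O)NCc1cc(Cl)ccc1-n1cnnn1` has not yet been measured in this assay. It differs from compound 3 in one place: tert-butyl in place of phenyl on a saturated chain carbon bound to a carbonyl carbon and an oxygen on a saturated carbon. Within the data shown here, no measured pair in the set isolates this change, so the expectation can only lean on the values of the tert-butyl-bearing compound 1 and compound 2 on the one hand and the limit of compound 3 on the other. The expected step is an at least 2.6-fold higher number from compound 3 to compound 4 (0.42 log units; beyond the scatter), a move towards faster removal, larger than the scatter. Compound 4 is therefore estimated at 40 mL.min-1.g-1 in this assay, with a range from 15 mL.min-1.g-1 to 90 mL.min-1.g-1.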

Compound 4, intrinsic clearance in microsomes: 22 mL.min-1.g-1
Beside the measured number, compound 4's estimate is 1.8-fold (0.26 log units) above it; the measured number falls inside the stated range.
By their numbers in this assay, from the lowest: compounds 4, 2 and 1 (each within the scatter of the next, the first and the last beyond it). At a limit, below all of these: compound 3.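

The change from phenyl to tert-butyl on a saturated chain carbon bound to a carbonyl carbon and an oxygen on a saturated carbon can now be read directly in this assay, as an at least 1.4-fold higher number from compound 3 to compound 4 (0.16 log units; that floor lies within the scatter). This reading is only a floor, because compound 3 stands at a limit of the assay and not at a number: the limit of < 15 mL.min-1.g-1 in this assay, at which 1 of the 4 values shown sits. The floor lies within the scatter, so the pair gives the direction of the step but does not establish a rise beyond the scatter.

The compounds shown leave open how far compound 3 lies under its limit, and so the true size of the step. They also leave open how a cyclohexyl group or a carboxylic acid at this position would read in this assay.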